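Amide to Urea on a Scaffold Without Measurable Toxicity

The source may report more compounds than this note shows. Statements on the series, on what has been measured and on what is new or still open speak of the compounds shown alone.

Two members of this series have been characterised in a functional assay on CAKI-1 cells (Homo sapiens) for inhibition, read by sulforhodamine B assay, with a stated time of 48 h; on this read-out lower numbers stand for higher toxicity in this test and higher numbers for lower toxicity in this test. Compound 1 `O=C(Nc1cccc(-n2cc(-c3ccncc3)c(-c3ccc(Cl)c(O)c3)n2)c1)Nc1cccc(C(F)(F)F)c1` returned only a limit, > 32500 nM, which is where the limit of > 32500 nM in this assay, at which 1 of the 2 values shown sits, sits. Compound 2 `COc1cc(-c2nn(-c3cccc(NC(=O)c4cccc(C(F)(F)F)c4)c3)cc2-c2ccncc2)ccc1Cl` likewise returned only a limit, > 50000 nM, corresponding to the limit of > 50000 nM in this assay, at which 1 of the 2 values shown sits. Within the data shown here, since neither compound produced a number, no measured step between them exists; the two values show only that no toxicity was found within the tested range for either.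

Compound 3 `COc1cc(-c2nn(-c3cccc(NC(=O)Nc4ccc(Cl)c(Cl)c4)c3)cc2-c2ccncc2)ccc1Cl` has not yet been tested. It differs from compound 2 in a single place: (3,4-dichlorophenyl)amino in place of 3-(trifluoromethyl)phenyl on a carbonyl carbon. In other words, the amide of compound 2 becomes a urea carrying a dichlorophenyl group. Compound 1 already pairs a urea with the same core type and in this assay compound 1 gave only > 32500 nM. On that basis the expected step from compound 2 to compound 3 is a number no higher from compound 2 to compound 3 (the limit leaves the size open), that is, nothing beyond the scatter and most probably another limit. Compound 3 is therefore estimated at about 50000 nM in this assay, with a range from 20000 nM to 150000 nM.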

Compound 3, concentration lethal to 50% of the cells: > 50000 nM
Compound 3 was reported as a limit; the forecaster's own chance of this, stated with the estimate: 80%; the middle value lies on the limit itself.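

In this assay compound 3 returned only a limit, > 50000 nM. Compound 2 also stands only as a limit, so no step can be read between compound 2 and compound 3. The compounds shown leave open whether replacing 3-(trifluoromethyl)phenyl with (3,4-dichlorophenyl)amino changes toxicity to these cells at all, and whether any of them would give a measurable value in this assay.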